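The source may hold more compounds than are shown below. What is called first, only, known or untested is meant among the compounds shown, and "the series" means these compounds.

Working notes on the series. Compound 1 `O=C(Nc1ccc(Cl)cc1F)c1ccccc1` is the plainest member. In an ADME assay on RAW264.7 cells (Mus musculus) for cytotoxicity, read by MTT assay, with a stated time of 24 h (on this read-out lower numbers stand for higher toxicity in this test and higher numbers for lower toxicity in this test), compound 1 gives only a limit, > 40000 nM. Compound 2 `COc1ccc(C(=O)Nc2ccc(Cl)cc2F)cc1` adds a methoxy to the core of compound 1. In this assay compound 2 likewise gives only a limit, > 40000 nM. The step that the two limits leave unreadable from compound 2 to compound 1 is the change (hydrogen in place of methoxy on an aromatic carbon); with both values at the limit its size cannot be read. Compound 3 `COc1ccccc1C(=O)Nc1ccc(I)cc1F` differs from compound 2 in more than one place, and the difference between the two cores is not broken down here. In this assay compound 3 gives only a limit, > 40000 nM. What the measured values show is the limit of > 40000 nM in this assay, at which 3 of the 3 values shown sit.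

Compound 4 `O=C(Nc1ccc(I)cc1F)c1ccccc1` is not yet measured. It differs from compound 3 by hydrogen in place of methoxy on an aromatic carbon. Set beside the change from compound 2 to compound 1, the place is not the same: in compound 3 the methoxy sits ortho to a large group, in compound 2 para to a large group, so the two are the same kind of change, not the same change. The earlier step gave no readable size, and the expected step that the limit leaves unreadable from compound 3 to compound 4 rests only on (the limit of > 40000 nM in this assay, at which 3 of the 3 values shown sit), where compound 3 also sits. Compound 4 is therefore expected to sit at that limit as well, with an estimate of 60000 nM and a range from 30000 nM to 200000 nM in this assay.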

Compound 4, half-maximal cytotoxic concentration: > 40000 nM
Compound 4: no number, only a limit (the forecaster's own chance of this, stated with the estimate: 80%); the middle value is on the limit's open side.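

For the compounds shown here, the steps from compound 3 to compound 4 and from compound 1 to compound 4 cannot be read, so no new step comes from these results. What the compounds shown leave open is whether swapping hydrogen for methoxy or iodo for chloro on the shared core shifts the read-out in this assay at all, with only this to go on: the limit of > 40000 nM in this assay, at which 4 of the 4 values shown sit.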